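Swapping a dimethylphenyl amide for a chlorophenyl amide

The compounds below may be only part of what the source reports. "The series", "measured", "known", "first", "only" and "open" are said of these compounds alone.

Of the compounds shown here, three sharing one core have been tested in a functional assay on CHO cells for antagonist activity at Orexin/Hypocretin receptor type 1 (Homo sapiens), read by FLIPR and calcium flux; a higher number here means a weaker inhibitor, a lower number a stronger inhibitor. Compound 1 `Cc1ccc(C)c(NC(=O)CSc2nnc(-c3ccoc3C)n2Cc2ccco2)c1` gives only a limit of the assay, > 15800 nM. Compound 2 `Cc1cccc(NC(=O)CSc2nnc(-c3ccoc3C)n2Cc2ccco2)c1C` likewise gives only a limit, > 15800 nM. Compound 3 `Cc1occc1-c1nnc(SCC(=O)Nc2ccc(F)c(Cl)c2)n1Cc1ccco1` gives a measured number, 1000 nM. So compound 2 sits at the limit shared by two of the three values (the limit of > 15800 nM in this assay, at which 2 of the 3 values shown sit), and the step that the two limits leave unreadable from compound 1 to compound 2 cannot be read from those two limits.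

Compound 4 `Cc1occc1-c1nnc(SCC(=O)Nc2cccc(Cl)c2)n1Cc1ccco1` is the unmeasured one. Its change from compound 2 is 3-chlorophenyl in place of 2,3-dimethylphenyl on an amide-type nitrogen.

The measured steps that bear on this are an at least 15-fold lower number from compound 2 to compound 3 (1.19 log units; beyond the scatter) and an at least 15-fold lower number from compound 1 to compound 3 (1.19 log units; beyond the scatter): in both, a halogen-bearing phenyl in place of a dimethylphenyl on the amide-type nitrogen brought the number down from the limit to a measured value. Compound 4 carries a 3-chlorophenyl, sharing the chlorine with compound 3 but lacking its fluorine, so a drop of similar kind, perhaps somewhat smaller, is expected in this assay, giving an at least 6.3-fold lower number from compound 2 to compound 4 (0.80 log units; beyond the scatter).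

Compound 4 is therefore estimated at 2500 nM in this assay, with a range from 700 nM to 12000 nM.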

Compound 4, inhibition constant: 2000 nM
The estimate for compound 4 lay 1.3-fold (0.10 log units) above the measured number, within the range that was stated.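

In this assay, a single chlorine on the phenyl ring is enough for a measured value, with the 3-chlorophenyl giving an at least 7.9-fold lower number from compound 2 to compound 4 (0.89 log units; beyond the scatter) and an at least 7.9-fold lower number from compound 1 to compound 4 (0.89 log units; beyond the scatter). Compound 1 and compound 2 each stand at a limit of the assay and not at a number, so these two steps give only the smallest size the change could have: the limit of > 15800 nM in this assay, at which 2 of the 4 values shown sit. Hydrogen in place of fluoro on an aromatic carbon gives a 2.0-fold higher number from compound 3 to compound 4 (0.30 log units; within the scatter), so compound 4 shows that this fluoro is not required for a measured value at this position.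

From the compounds shown here alone, compound 2 and compound 4 differ in both the methyl groups and the chlorine, so it remains open whether the gain comes from the chlorine arriving or the methyl groups leaving, and a plain phenyl would help to separate the two. Also open, going by these compounds, is how a bromine, a methoxy or a trifluoromethyl in place of the chlorine would read in this assay.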